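From aminomethyl to methyl on a glucose-derived core

A few compounds are considered here, and "the series" means these few. Any claim that something is new, unique, unknown or untested is made for them only; others in the source may bear on it.

Of the compounds shown here, two sharing a glucose-derived core have been measured in an assay on isolated protein (Oryctolagus cuniculus) for binding affinity to glycogen phosphorylase, brain form (Homo sapiens); on this read-out higher numbers stand for weaker inhibition and lower numbers for stronger inhibition. Compound 1 `O=C(Nc1ccccc1)[C@@H]1OC(CO)C(O)C(O)C1O` carries an anilide on the core; in this assay compound 1 gives 5400000 nM. Among the measured compounds shown here, compound 2 `NC[C@H]1OC(CO)C(O)C(O)C1O` carries an aminomethyl group instead, and in this assay compound 2 gives 34500000 nM, the highest of the two numbers, with compound 1 as its only neighbour and the gap between them beyond the usual scatter.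

Compound 3 `C[C@H]1OC(CO)C(O)C(O)C1O` differs from compound 2 in one place: hydrogen in place of amino on a saturated chain carbon bound to a saturated ring carbon. For the measured compounds named here, no measured pair shows this change, so the expected step rests on judgement alone. The step in this assay is expected to be a modest move towards a lower number, of about a 1.9-fold lower number from compound 2 to compound 3 (0.28 log units; within the scatter), not certainly beyond the scatter. Compound 3 is therefore expected to give about 18000000 nM, with a plausible range from 5000000 nM to 70000000 nM.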

Compound 3, inhibition constant: 53100000 nM
Beside the measured number, compound 3's estimate is 3.0-fold (0.47 log units) below it; measured number inside the range.
By their numbers in this assay, from the lowest: compound 1; then compounds 2 and 3 (each within the scatter of the next).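

In this assay, exchanging the amino group for hydrogen on this saturated chain carbon gives a 1.5-fold higher number from compound 2 to compound 3 (0.19 log units; within the scatter). The step from aminomethyl to methyl therefore gives no sign that the amino group, at this place and on this read-out, matters: compound 2 and compound 3 cannot be told apart here, so neither the nitrogen nor its hydrogen-bond donor and acceptor count shows up in the number. Nothing available explains why this exchange leaves the two numbers within the scatter of each other.

Going by these compounds, what remains open is whether a carboxylic acid, a hydroxymethyl group or a longer chain at this place would move the number beyond the scatter. Also open, on these data alone, is how a primary amide or an acetamide on the shared core would read.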